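The source may report more compounds than this note shows. Statements on the series, on what has been measured and on what is new or still open speak of the compounds shown alone.

- compound 1 `COc1ccc(Cc2nnc(NC(=O)/C(C#N)=C/c3ccccc3OS(=O)(=O)c3ccc(Cl)cc3)s2)cc1`: 20%
- compound 2 `Cc1ccc(S(=O)(=O)Oc2ccccc2/C=C(\C#N)C(=O)Nc2nnc(Cc3ccccc3)s2)cc1`: 16%
- compound 3 `N#C/C(=C\c1ccccc1OS(=O)(=O)c1ccc([N+](=O)[O-])cc1)C(=O)Nc1nnc(Cc2ccccc2)s1`: 20%

All three values come from a functional assay on HL-60 cells (Homo sapiens) for inhibition, read by CCK-8 assay, with a stated time of 48 h, tested at 20 uM; on this read-out higher numbers stand for more inhibition of growth at the one concentration tested and lower numbers for less inhibition of growth. Compound 3 at 20% is level with compound 1 and lies within the scatter of compound 2, so the three compounds are not separated on this read-out.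

The next compound is compound 4 `N#C/C(=C\c1ccccc1OS(=O)(=O)c1ccc(Cl)cc1)C(=O)Nc1nnc(Cc2ccccc2)s1`, which turns the 4-nitrophenyl of compound 3 into 4-chlorophenyl, chloro in place of nitro on an aromatic carbon.

Within the data shown here, one measured step bears directly on this place: nitro in place of methyl gave a number 4 percentage points higher from compound 2 to compound 3 (within the scatter). Compound 4 also shares its 4-chlorophenyl group with compound 1, which differs elsewhere and gives 20%. No measured change at this place has yet moved the number beyond the scatter, so no step beyond the scatter is expected in this assay. The expected step is a number 1 percentage points lower from compound 3 to compound 4 (within the scatter). The estimated value for compound 4 is 19%, with an expected range of 10% to 28%.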

Compound 4, percent growth inhibition at one concentration: 26%
Compound 4: middle estimate off by 7 percentage points, on the low side; the measured number falls inside the stated range.
By their numbers in this assay, from the lowest: compounds 2, 1, 3 and 4 (each within the scatter of the next).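

With chloro in this assay, the place that carries the 4-nitrophenyl group of compound 3 now has three groups compared: a number 6 percentage points higher from compound 3 to compound 4 (within the scatter) and a number 10 percentage points higher from compound 2 to compound 4 (within the scatter), so methyl, nitro and chloro remain unseparated on this read-out. The series also gains its first reading at a second place, hydrogen in place of methoxy on an aromatic carbon, where a number 6 percentage points higher from compound 1 to compound 4 (within the scatter), so neither place has yet moved the number beyond the scatter. No measured data are available to explain these steps.

As far as these compounds go, it remains open whether an amine or a carboxylic acid at the place of the chloro, or a longer chain at the place of the methoxy, would give a step beyond the scatter. A single concentration also leaves open how these compounds would compare across a range of concentrations.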